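This account rests on a few compounds, and the source may have more. Where it says the series, first, only, none or still open, it means among the compounds named here.

In a functional assay on BGC-823 cells (Homo sapiens) for cytotoxicity, read by CCK-8 assay, with a stated time of 72 h (on this read-out higher numbers stand for weaker inhibition and lower numbers for stronger inhibition), compound 1 `COc1ccccc1/C=c1/[nH]c(=O)/c(=C\c2cccc(Cl)c2Cl)[nH]c1=O` gives "not active" (no number reported), so no number stands for it. Compound 2 `C=CCn1c(=O)/c(=C\c2cccc(Cl)c2Cl)[nH]c(=O)/c1=C\c1ccccc1OC` is measured in this assay at 2200 nM, the only figure in the set; nothing further can be said of where it ranks. For the measured compounds named here, compound 3 `C=CCn1c(=O)/c(=C\c2cccc(Br)c2)[nH]c(=O)/c1=C\c1ccccc1OC` carries 3-bromophenyl in place of 2,3-dichlorophenyl on a double-bonded chain carbon bound to an aromatic carbon, and no measured pair shows what such a change does here. The expected step from compound 2 to compound 3 in this assay is a 1.6-fold higher number from compound 2 to compound 3 (0.20 log units; within the scatter), a modest weakening that may not exceed the scatter. For compound 3 the estimate is 3500 nM, expected between 1000 nM and 12000 nM.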

Compound 3, half-maximal inhibitory concentration: 5900 nM
Compound 3: the middle estimate sits 1.7-fold (0.23 log units) below what was measured; the range from low to high includes it.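

In this assay, 3-bromophenyl in place of 2,3-dichlorophenyl gives a 2.7-fold higher number from compound 2 to compound 3 (0.43 log units; beyond the scatter) and so shows that the group on this double-bonded chain carbon does affect the result. The lower number stays with 2,3-dichlorophenyl. This single step changes both the halogen and the number of halogens, so it cannot separate the two changes. Going by these compounds, how a phenyl carrying an amine or a carboxylic acid would behave at this place remains open. No available evidence explains the size of this step.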